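The source may report more compounds than this note shows. Statements on the series, on what has been measured and on what is new or still open speak of the compounds shown alone.

Measured in a functional assay on PANC-1 cells (Homo sapiens), read by microscopy, crystal violet staining and transwell migration, with a stated time of 18 h, in the presence of a further agent that is not named here; on this read-out lower numbers stand for stronger inhibition and higher numbers for weaker inhibition:
- compound 1 `CCCCc1nc(-c2ccc(OC)cc2)n(-c2cccc(C(=O)NCCCCc3ccccc3)c2)n1`: 16800 nM
- compound 2 `COc1ccc(-c2nc(C3CC3)nn2-c2cccc(C(=O)NCCCCc3ccccc3)c2)cc1`: 7680 nM
- compound 3 `CCOc1ccc(-c2nc(CC)nn2-c2cccc(C(=O)NCCCCc3ccccc3)c2)cc1`: 16800 nM

Compound 3 shows the same number as compound 1, and these two share the highest value of the three. Compound 2 lies lower, beyond the scatter.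

The next compound to be tested is compound 4 `CCc1nc(-c2ccc(OC)nc2)n(-c2cccc(C(=O)NCCCCc3ccccc3)c2)n1`. It differs from compound 3 as follows: 6-methoxypyridin-3-yl in place of 4-ethoxyphenyl on an aromatic carbon. The change is 6-methoxypyridin-3-yl in place of 4-ethoxyphenyl, on an aromatic carbon of a five-membered aromatic ring with 3 nitrogen. The ethyl group stays.

Among the measured compounds shown here, only one measured step bears on this series, a 2.2-fold lower number from compound 1 to compound 2 (0.34 log units; beyond the scatter). It is modest and exchanges butyl for cyclopropyl, so it says nothing directly about the change made here. For the measured compounds named here, no measured step removes 4-ethoxyphenyl or introduces 6-methoxypyridin-3-yl. The expectation in this assay therefore rests on compound 3 at 16800 nM, with no clear direction and no shift beyond the scatter anticipated. The expected step is a 1.2-fold lower number from compound 3 to compound 4 (0.08 log units; within the scatter), which is small and uncertain. For compound 4 the estimated value is 14000 nM, with an expected range of 6000 nM to 32000 nM.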

Compound 4, half-maximal inhibitory concentration: 810 nM
The estimate for compound 4 lay 17-fold (1.24 log units) above the measured number, and the stated range ends above it.
By their numbers in this assay, from the lowest: compound 4; then compound 2; then compounds 1 and 3 (each within the scatter of the next).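

In this assay, replacing 4-ethoxyphenyl with 6-methoxypyridin-3-yl while the ethyl group stays gives a 21-fold lower number from compound 3 to compound 4 (1.32 log units; beyond the scatter) and shows that this aromatic carbon of the five-membered ring, next to the ring atom that bears a large group, is sensitive to the identity of its aryl substituent. Among the compounds shown here, the only earlier step, a 2.2-fold lower number from compound 1 to compound 2 (0.34 log units; beyond the scatter) on exchanging butyl for cyclopropyl, concerned the alkyl group and was modest, so the aryl change is the largest effect seen so far, though this rests on one pair of compounds. No measurement available here explains the size of this step.

The step combines two changes, a ring nitrogen entering and ethoxy giving way to methoxy, and the compounds shown do not separate them; a 6-ethoxypyridin-3-yl group on the same ethyl-bearing core would isolate the ring nitrogen. Also open, going by these compounds, is whether the gain carries over to the butyl and cyclopropyl analogues, and how a 6-aminopyridin-3-yl group would compare at this position.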